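Trifluoromethyl to phenyl: a question of growth inhibition

A few compounds are considered here, and "the series" means these few. Any claim that something is new, unique, unknown or untested is made for them only; others in the source may bear on it.

compound 1 `C/C(=N/O)c1ccc(NC(=O)Cn2nc(C(F)(F)F)nc2N)cc1` gives 11.3%
compound 2 `COc1cc(-c2nc3sc(-c4ccccc4)cn3n2)cc(OC)c1OC` gives 32%
compound 3 `COc1cc(-c2nc(N)n(CC(=O)Nc3ccc(/C(C)=N\O)cc3)n2)cc(OC)c1OC` gives 14.2%

All three were tested in a functional assay on U-251 cells (Homo sapiens) for inhibition, read by sulforhodamine B assay, with a stated time of 48 h, tested at 10 uM (a lower number here means less inhibition of growth, a higher number more inhibition of growth at the concentration tested), and the numbers are low to moderate. Compound 1, at 11.3% in this assay, lies within the scatter of compound 3, so those two cannot be told apart. Compound 2 stands higher than compound 1 by more than the scatter.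

The next compound to be measured is compound 4 `C/C(=N/O)c1ccc(NC(=O)Cn2nc(-c3ccccc3)nc2N)cc1`, which has phenyl in place of trifluoromethyl on an aromatic carbon of compound 1. Among the compounds with values here, no measured pair here shows the effect of such a change directly, so the evidence is thin. Compound 3 also carries a six-membered aromatic ring on that carbon, and compound 3 gives 14.2% in this measurement. That points to little change. The expected step of a number 3.7 percentage points higher from compound 1 to compound 4 (within the scatter) is small and stays within the scatter, with no clear direction. For compound 4 the estimated value is 15% with an expected range from 4% to 29% in this measurement.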

Compound 4, percent growth inhibition at one concentration: 8.76%
Compound 4: middle estimate off by 6.2 percentage points, on the high side, and the stated range covers the measured number.
By their numbers in this assay, from the lowest: compounds 4, 1 and 3 (each within the scatter of the next); then compound 2.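

In this assay, within the data shown here, the first direct comparison at this aromatic carbon, between two ring nitrogen atoms, shows that replacing trifluoromethyl with phenyl gives a number 2.5 percentage points lower from compound 1 to compound 4 (within the scatter). The two compounds therefore cannot be told apart, even though the incoming group is larger and brings a six-membered aromatic ring of its own. Growth inhibition stays low with either group at the concentration tested, and no measurement shown here offers an explanation for this result.

From the compounds shown here alone, it remains open whether any group on this carbon can move the number beyond the usual scatter, and an amine, a carboxylic acid or a longer chain would each test that. Also open, going by these compounds, is whether phenyl and trifluoromethyl would still read alike at other concentrations or in other cell lines.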